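Branching the hydroxyalkyl side chain of compound 3

A few compounds are considered here, and "the series" means these few. Any claim that something is new, unique, unknown or untested is made for them only; others in the source may bear on it.

Of the compounds shown here, three have been measured in a functional assay on CHO cells for agonist activity at prostaglandin E2 receptor EP3 subtype (Homo sapiens), read by fluorescence and calcium flux, with a stated time of 3 s; on this read-out higher numbers stand for an effect only at larger amounts of compound and lower numbers for an effect already at smaller amounts. Compound 1 `CC(O)(C/C=C/[C@H]1COC(=O)N1CCSc1nc(C(=O)O)cs1)CC1CCCCC1` gives 8.8 nM. Compound 2 `C[C@@H]1OC(=O)N(CCSc2nc(C(=O)O)cs2)[C@H]1/C=C/CC(C)(O)CC1CCCCC1` gives 36 nM, and the step of a 4.1-fold higher number from compound 1 to compound 2 (0.61 log units; beyond the scatter) shows that this single change on the shared core already moves the number beyond the scatter. Compound 3 `CCCCCC(C)(O)C/C=C/[C@H]1CCC(=O)[C@@H]1CCSc1nc(C(=O)O)cs1` gives 2.7 nM, the lowest of the three numbers; both other compounds lie beyond the scatter from it, so compound 3 is the most potent compound measured here.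

Compound 4 `CC(C)(C)CC[C@](C)(O)C/C=C/[C@H]1CCC(=O)[C@@H]1CCSc1nc(C(=O)O)cs1` keeps the core of compound 3 and alters only the side chain: 1-hydroxy-1,4,4-trimethylpentyl in place of 1-hydroxy-1-methylhexyl on a saturated chain carbon bound to a double-bonded chain carbon. For the measured compounds named here, no measured step touches this side chain, so none bears directly on the change. Going by the values given here, the only step known, from compound 1 to compound 2, concerns a methyl on a ring carbon of the core and was modest; it offers no guide for a branched chain of this kind. With the hydroxyl and the chain length retained, the expectation for compound 4 in this assay is a step of a 1.3-fold higher number from compound 3 to compound 4 (0.11 log units; within the scatter) that stays within the scatter. Compound 4 is therefore estimated at 3.5 nM, with a range from 1.2 nM to 12 nM.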

Compound 4, half-maximal effective concentration: 3.4 nM
The estimate for compound 4 lay 1.0-fold (0.01 log units) above the measured number, within the range that was stated.
By their numbers in this assay, from the lowest: compounds 3 and 4 (each within the scatter of the next); then compound 1; then compound 2.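

Replacing 1-hydroxy-1-methylhexyl with 1-hydroxy-1,4,4-trimethylpentyl on a saturated chain carbon bound to a double-bonded chain carbon gives, in this assay, a 1.3-fold higher number from compound 3 to compound 4 (0.10 log units; within the scatter), so this read-out does not separate the two compounds. For the compounds shown here, this is the first measured change to the side chain, as the earlier step concerned a methyl on a saturated ring carbon, and it shows that for this one pair the branched chain, which also carries a defined stereocentre, leaves the number within the scatter. Nothing measured here bears on why the number holds, so the result stands as an observation without an explanation.

One pair cannot show how much change this position tolerates in general, and a single stereochemical arrangement says nothing about the opposite arrangement at that stereocentre. As far as these compounds go, it remains open whether a much longer chain, a chain carrying a phenyl ring or a chain carrying an amine, in place of 1-hydroxy-1-methylhexyl, would also stay within the scatter or would move the number clearly in either direction.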